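Methoxy added to the aryl ring of compound 2

A few compounds are considered here, and "the series" means these few. Any claim that something is new, unique, unknown or untested is made for them only; others in the source may bear on it.

Two numbers stand so far. Compound 2 `COc1ccc(/C(Cl)=C/C=C(\C#N)C(=O)c2c(C)[nH]c3ccccc23)cc1OC` in an ADME assay on Vero cells (Chlorocebus sabaeus) for cytotoxicity, read by sulforhodamine B assay, with a stated time of 48 h (a lower number here means a stronger inhibitor of growth, a higher number a weaker inhibitor of growth), gives 11800 nM, the lower of the two, while compound 1 `COc1cc(/C(Cl)=C/C=C(\C#N)C(=O)c2c[nH]c3ccccc23)cc(OC)c1OC` in this assay gives 16200 nM; the gap between them lies within the scatter. Compound 3 `COc1cc(/C(Cl)=C/C=C(\C#N)C(=O)c2c(C)[nH]c3ccccc23)cc(OC)c1OC` differs from compound 2 by methoxy in place of hydrogen on an aromatic carbon. Within the data shown here, no step between measured compounds matches this change, so in this assay no shift beyond the scatter is expected, in either direction. For compound 3 the estimate is 14000 nM, with a range from 6000 nM to 33000 nM, which corresponds to an expected step of a 1.2-fold higher number from compound 2 to compound 3 (0.07 log units; within the scatter).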

Compound 3, concentration for 50% growth inhibition: 12400 nM
Compound 3: middle estimate off by 1.1-fold (0.05 log units), on the high side; measured number inside the range.
By their numbers in this assay, from the lowest: compounds 2, 3 and 1 (each within the scatter of the next).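

In this assay, methoxy in place of hydrogen on an aromatic carbon, ortho to a methoxy group and meta to a large group, gives a 1.1-fold higher number from compound 2 to compound 3 (0.02 log units; within the scatter) and so moves the number no further than the scatter. Methyl in place of hydrogen on an aromatic carbon gives a 1.3-fold lower number from compound 1 to compound 3 (0.12 log units; within the scatter) and also stays within the scatter. Neither single change separates these compounds here.

Open, from the compounds shown here alone, is whether an amine, a carboxylic acid or a longer alkoxy chain at this methoxy position would give a step beyond the scatter. No supporting measurement bears on these results.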